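Swapping Hexyl for Pyridin-3-yl in Compound 4

A few compounds are considered here, and "the series" means these few. Any claim that something is new, unique, unknown or untested is made for them only; others in the source may bear on it.

In a functional assay on HeLa cells (Homo sapiens) for cytotoxicity, read by WST assay, with a stated time of 48 h (on this read-out lower numbers stand for stronger inhibition and higher numbers for weaker inhibition), compound 1 `CCCCCC/C=C/C[C@H]1C[C@@H]([C@@H](O)c2ccccc2)CO[C@@H]1c1ccccc1` gives 7400 nM, the lowest of the three numbers shown. Compound 3 `COc1ccc(/C=C/C[C@H]2C[C@@H]([C@@H](O)c3ccccc3)CO[C@@H]2c2ccc(OC)c(OC)c2)cc1OC` gives 15500 nM, and compound 2 `COc1cccc(/C=C/C[C@@H]2C[C@@H]([C@@H](O)c3ccc(OC)c(OC)c3)CO[C@H]2c2ccc(OC)c(OC)c2)c1` gives 16400 nM; both gaps from compound 1 lie beyond the scatter, so compound 1 stands as the strongest of the three. Compound 4 `O[C@@H](c1ccccc1)[C@H]1CO[C@H](c2ccccc2)[C@@H](C/C=C/c2cccnc2)C1` has not yet been measured. It differs from compound 1 in one place (pyridin-3-yl in place of hexyl on a double-bonded chain carbon bound to a double-bonded chain carbon). Among the compounds with values here, compounds 2 and 3, which differ from compound 1 both in that place and elsewhere, give higher numbers, but no single-change step is at hand. A modest rise in the number is expected for compound 4, and the step of a 1.6-fold higher number from compound 1 to compound 4 (0.21 log units; within the scatter) is that estimate. Compound 4 is expected to give 12000 nM, within a range from 5000 nM to 30000 nM.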

Compound 4, half-maximal inhibitory concentration: > 100000 nM
Compound 4: no number, only a limit (the forecaster's own chance of this, stated with the estimate: 5%); middle value at least 8.3-fold (0.92 log units) from the limit.
By their numbers in this assay, from the lowest: compound 1; then compounds 3 and 2 (each within the scatter of the next). At a limit, above all of these: compound 4.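

In this assay, pyridin-3-yl in place of hexyl on a double-bonded chain carbon bound to a double-bonded chain carbon gives an at least 13-fold higher number from compound 1 to compound 4 (1.13 log units; beyond the scatter), the first step read at this place with nothing else changed. Compound 4 has only a limit and no number: the limit of > 100000 nM in this assay, at which 1 of the 4 values shown sits. This single change thus takes the read-out to that limit, which compounds 2 and 3, changed elsewhere as well, could not show.

The compounds shown leave open whether the ring nitrogen or the absence of the hexyl chain matters. A plain phenyl or a butyl chain at this place would separate the two.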